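One chain swap: what compound 3 may do

This account rests on a few compounds, and the source may have more. Where it says the series, first, only, none or still open, it means among the compounds named here.

compound 1 `CCOC(=O)CN(C)CC(=O)NNC(=O)COc1ccc(-c2nc3ccccc3s2)cc1OC`: 1980 nM
compound 2 `CCOC(=O)[C@H](CS)N(CC(=O)NNC(=O)COc1ccc(-c2nc3ccccc3s2)cc1OC)C(C)=O`: 1890 nM

Both numbers come from a functional assay on MCF7 cells (Homo sapiens) for inhibition, read by MTT assay, with a stated time of 3 days; a lower number here means a stronger inhibitor, a higher number a weaker inhibitor. There, compound 2 gives 1890 nM and compound 1 gives 1980 nM, so the two sit within the usual scatter of each other and neither can be ranked above the other.

The next compound is compound 3 `CCOC(=O)[C@H](CCSC)NCC(=O)NNC(=O)COc1ccc(-c2nc3ccccc3s2)cc1OC`. It keeps the shared core, and on a saturated chain carbon bound to a carbonyl carbon it carries (1-(ethoxycarbonyl)-3-(methylsulfanyl)propyl)amino in place of acetyl(1-(ethoxycarbonyl)-2-sulfanylethyl)amino on a saturated chain carbon bound to a carbonyl carbon.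

Going by the values given here, only one measured step bears on this change. It is a 1.0-fold lower number from compound 1 to compound 2 (0.02 log units; within the scatter), made at the same place, and it brought in the very group that now leaves. That large exchange of groups did not move the number beyond the scatter, so no step beyond the scatter is expected in this assay here either, in either direction. One step is thin evidence, so the range stays wide.

The expected change is a 1.0-fold higher number from compound 2 to compound 3 (0.00 log units; within the scatter). For compound 3 the estimated value is 1900 nM, with an expected range of 800 nM to 4500 nM.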

Compound 3, half-maximal inhibitory concentration: 1760 nM
For compound 3 the middle estimate is 1.1-fold (0.03 log units) above the measured one; the range from low to high includes it.
By their numbers in this assay, from the lowest: compounds 3, 2 and 1 (each within the scatter of the next).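

This result adds a third amino group at the same place, on a saturated chain carbon bound to a carbonyl carbon, and in this assay the swap gives a 1.1-fold lower number from compound 2 to compound 3 (0.03 log units; within the scatter), so losing the acetyl and taking on the (methylsulfanyl)propyl chain does not separate these two compounds. Compared directly with the smaller ((ethoxycarbonyl)methyl)(methyl)amino group, the new group gives a 1.1-fold lower number from compound 1 to compound 3 (0.05 log units; within the scatter), so all three compounds now sit within the scatter of one another, and none of the three groups can be ranked above the others. Nothing available here says why such different groups leave the number in this narrow band, which is a statement about these three compounds only, not about the position in general.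

On these data alone, all three groups still carry the ethoxycarbonyl ester and a nitrogen bound to the chain carbon, so it remains open whether a carboxylic acid in place of that ester, or a ring amine such as morpholine at the same place, would move the number beyond the scatter. Whether the shared core, rather than this chain, sets the level of the number also stays unanswered.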